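Methyl in Place of Methoxy: Expected Cytotoxicity of Compound 4

A few compounds are considered here, and "the series" means these few. Any claim that something is new, unique, unknown or untested is made for them only; others in the source may bear on it.

Three compounds have been measured in an ADME assay on THP-1 cells (Homo sapiens) for cytotoxicity, read by MTT assay; on this read-out higher numbers stand for lower toxicity in this test and lower numbers for higher toxicity in this test:
compound 1 `Cc1nc(-c2cccnc2)sc1-c1nnc(Cc2ccccc2)o1` gives the limit > 100 ug/mL
compound 2 `Cc1nc(-c2cccnc2)sc1-c1nnc(-c2ccc([N+](=O)[O-])cc2)o1` gives the limit > 100 ug/mL
compound 3 `COc1ccccc1-c1nnc(-c2sc(-c3cccnc3)nc2C)o1` gives the limit > 100 ug/mL

Each of these values is a limit of the assay, not a number. Compound 3 thus stands at the limit of > 100 ug/mL in this assay, at which 3 of the 3 values shown sit, together with the other two. Going by the values given here, the single step between measured neighbours, a step that the two limits leave unreadable from compound 1 to compound 3, has no readable size; both of its ends are limits. Compound 4 `Cc1ccccc1-c1nnc(-c2sc(-c3cccnc3)nc2C)o1` differs from compound 3 by methyl in place of methoxy on an aromatic carbon. Among the compounds with values here, no measured step bears on this change, and the three limits give no direction to expect. Compound 4 is therefore expected to sit at the same limit, with the step that the limit leaves unreadable from compound 3 to compound 4 estimated as no change beyond the scatter. The estimate for compound 4 is 150 ug/mL, ranging from 60 ug/mL to 400 ug/mL.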

Compound 4, half-maximal cytotoxic concentration: > 100 ug/mL
Compound 4 gave a limit, no number (the forecaster's own chance of this, stated with the estimate: 85%); the middle value is on the limit's open side.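

Going by these compounds alone, no step from compound 1 or compound 3 to compound 4 can be read, since both ends of each are limits of the assay. The compounds shown leave open where any of them truly stands in this assay, and whether methyl in place of methoxy changes the read-out at all.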